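Changing the Group on the Ring Amine: Compound 4

The source may report more compounds than this note shows. Statements on the series, on what has been measured and on what is new or still open speak of the compounds shown alone.

Compound 1 `c1ccc(OCc2nc3c(OCCCN4CCCCC4)cccc3n2CCCC2CCNCC2)cc1` gives 4.5 nM in an in vitro assay on AV12 cells for binding affinity to Neuropeptide Y receptor type 1 (Homo sapiens); a higher number here means a weaker inhibitor, a lower number a stronger inhibitor.
Compound 2 `c1ccc(OCc2nc3c(OCCCN4CCCCC4)cccc3n2CCCC2CCN(CC3CCCCC3)CC2)cc1` gives 0.393 nM in this assay.
Compound 3 `CC(C)CCN1CCC(CCCn2c(COc3ccccc3)nc3c(OCCCN4CCCCC4)cccc32)CC1` gives 0.29 nM in this assay.

Among these three numbers compound 2 stands second highest. Its nearest neighbour is compound 3, separated by a step within the scatter, a 1.4-fold lower number from compound 2 to compound 3 (0.13 log units; within the scatter), while compound 1 lies far away, as the step of an 11-fold lower number from compound 1 to compound 2 (1.06 log units; beyond the scatter) shows.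

The new compound 4 `O=C(CCCN1CCC(CCCn2c(COc3ccccc3)nc3c(OCCCN4CCCCC4)cccc32)CC1)c1ccccc1` differs from compound 2 in one place: 2-benzoylethyl in place of cyclohexyl on a saturated chain carbon bound to an amine nitrogen in a ring. Within the data shown here, two measured steps bear on this position, an 11-fold lower number from compound 1 to compound 2 (1.06 log units; beyond the scatter) and a 16-fold lower number from compound 1 to compound 3 (1.19 log units; beyond the scatter); both show that putting a group onto that amine nitrogen in place of hydrogen brings a large gain in this assay. The step of a 1.4-fold lower number from compound 2 to compound 3 (0.13 log units; within the scatter) then shows that exchanging one such group for another leaves the number within the scatter. Compound 4 keeps a group on that nitrogen, so no step beyond the scatter is expected in either direction. For compound 4 the expected step is a 1.3-fold higher number from compound 2 to compound 4 (0.10 log units; within the scatter). The entering group carries a carbonyl that neither cyclohexyl nor isobutyl had, so the range is kept wide. Compound 4 is therefore expected to give 0.5 nM in this assay, within a range from 0.15 nM to 2 nM.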

Compound 4, inhibition constant: 0.132 nM
Compound 4: middle estimate off by 3.8-fold (0.58 log units), on the high side; the whole stated range lies above it.
By their numbers in this assay, from the lowest: compound 4; then compounds 3 and 2 (each within the scatter of the next); then compound 1.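

Until now, exchanging one group on this ring amine nitrogen for another had stayed within the scatter, but in this assay the 3-benzoylpropyl group stands apart, with a 3.0-fold lower number from compound 2 to compound 4 (0.47 log units; beyond the scatter) and a 2.2-fold lower number from compound 3 to compound 4 (0.34 log units; beyond the scatter) as well. The choice of group at this nitrogen therefore matters, although these steps are modest beside the large overall gain over hydrogen, seen in a 34-fold lower number from compound 1 to compound 4 (1.53 log units; beyond the scatter) for this same group. The entering group brings a carbonyl and an aromatic ring, features that the cyclohexyl and isobutyl compared earlier lack, but no measurement here explains the added gain.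

The compounds shown do not separate the part played by the carbonyl from that of the aromatic ring: a chain ending in phenyl with no carbonyl, or one with a hydroxyl group in place of the carbonyl, would address this. Also open, as far as these compounds go, is how the number responds to a shorter or longer chain before the benzoyl group, or to an amide in place of its ketone.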